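Swapping the alkynol chain for an ethylpyrazole

The source may hold more compounds than are shown below. What is called first, only, known or untested is meant among the compounds shown, and "the series" means these compounds.

In an ADME assay (liver) for metabolic stability, with Liver microsome (Homo sapiens) as the target, using microsomes and NADPH, with a stated time of 30 min, tested at 1 uM (on this read-out higher numbers stand for fast clearance and lower numbers for slow clearance), compound 1 (`Nc1ccc(S(=O)(=O)N2CCN(c3ncc(C(O)(C(F)(F)F)C(F)(F)F)cc3C#CCO)CC2)cn1`) gives < 14 mL.min-1.g-1 as a limit of the assay. Compound 2 (`Nc1ccc(S(=O)(=O)N2CCN(c3ncc(C(O)(C(F)(F)F)C(F)(F)F)cc3C#CCCO)CC2)cn1`) gives < 14 mL.min-1.g-1 which is likewise a limit and not a number. Among the compounds with values here, the one measured step (a step that the two limits leave unreadable from compound 1 to compound 2) offers no size to carry over, and the limit of < 14 mL.min-1.g-1 in this assay, at which 2 of the 2 values shown sit, is all the evidence at hand. Compound 3 (`CCn1cc(-c2cc(C(O)(C(F)(F)F)C(F)(F)F)cnc2N2CCN(S(=O)(=O)c3ccc(N)nc3)CC2)cn1`) carries 1-ethyl-1H-pyrazol-4-yl in place of 4-hydroxybut-1-yn-1-yl on an aromatic carbon. A modest upward step is expected (an at least 1.1-fold higher number from compound 2 to compound 3 (0.05 log units; that floor lies within the scatter)) though no measured step sizes it. For compound 3 the estimated clearance is 16 mL.min-1.g-1 with an expected range from 7 mL.min-1.g-1 to 40 mL.min-1.g-1 as its upper end.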

Compound 3, intrinsic clearance in microsomes: 20 mL.min-1.g-1
For compound 3 the middle estimate is 1.3-fold (0.10 log units) below the measured one; the measured number falls inside the stated range.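

In this assay, 1-ethyl-1H-pyrazol-4-yl on this aromatic carbon gives compound 3 a true number, whereas the two hydroxyalkynyl chains gave only a limit: the limit of < 14 mL.min-1.g-1 in this assay, at which 2 of the 3 values shown sit. The change reads as an at least 1.4-fold higher number from compound 2 to compound 3 (0.15 log units; that floor lies within the scatter), and as an at least 1.4-fold higher number from compound 1 to compound 3 (0.15 log units; that floor lies within the scatter). Both steps are floors, so the real size of the change remains unfixed, and the step between the two chains cannot be read.

On these data alone, it remains open whether the pyrazole ring or its ethyl group accounts for the number. A methyl group in place of that ethyl, or a pyrazole with no alkyl group, could separate the two.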